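Removing the Bromine from Compound 2

The compounds below may be only part of what the source reports. "The series", "measured", "known", "first", "only" and "open" are said of these compounds alone.

Three compounds share one core and differ only in the group carried on the aromatic nitrogen. In a functional assay on the whole organism (strain Albino Wistar) for inhibition, with Rattus norvegicus as the target, read by paw edema, with stated times of 1 h and 5 h, at a dose of 10 mg/kg by the oral route (a lower number here means less inhibition, a higher number more inhibition at the dose given (going by the name of the read-out)), compound 1 `Clc1ccccc1-n1cc(CSc2nc3ccccc3s2)nn1` gives 78.1%, compound 2 `Brc1ccc(-n2cc(CSc3nc4ccccc4s3)nn2)cc1` gives 59.2%, and compound 3 `Cc1ccccc1-n1cc(CSc2nc3ccccc3s2)nn1` gives 43.4%. Compound 2 thus stands second of the three: a number 18.9 percentage points lower from compound 1 to compound 2 (beyond the scatter), while a number 15.8 percentage points lower from compound 2 to compound 3 (beyond the scatter). The change from compound 2 to compound 4 `c1ccc(-n2cc(CSc3nc4ccccc4s3)nn2)cc1` is hydrogen in place of bromo on an aromatic carbon. Among the measured compounds shown here, no measured step removes a halogen outright; the closest comparison is a number 34.7 percentage points lower from compound 1 to compound 3 (beyond the scatter), and the two exchanges of the whole aryl group, a number 18.9 percentage points lower from compound 1 to compound 2 (beyond the scatter) and a number 15.8 percentage points lower from compound 2 to compound 3 (beyond the scatter), were both modest drops. Among the three measured compounds every move away from the chlorinated compound 1 has lowered the inhibition in this assay, so a drop beyond the scatter is expected here as well. For compound 4 the expected step is a number 15.2 percentage points lower from compound 2 to compound 4 (beyond the scatter). Compound 4 is therefore estimated at 44%, in a range from 30% to 58%.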

Compound 4, a percentage reported as inhibition, in the whole organism at one dose (the size of the read-out at that dose, not a potency): 32.1%
Beside the measured number, compound 4's estimate is 11.9 percentage points above it, within the range that was stated.
By their numbers in this assay, from the lowest: compound 4; then compound 3; then compound 2; then compound 1.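

In this assay, among the compounds shown here, the plain phenyl group of compound 4 gives the lowest number of the four, the first reading with no substituent on this ring: a number 27.1 percentage points lower from compound 2 to compound 4 (beyond the scatter), a number 11.3 percentage points lower from compound 3 to compound 4 (beyond the scatter) and a number 46 percentage points lower from compound 1 to compound 4 (beyond the scatter). Among the compounds shown, then, bromo, chloro and methyl on this ring each go with more inhibition than hydrogen, and no compound goes against this. For the compounds shown here, only the step from the 2-chlorophenyl compound is large, while the steps from the bromo and methyl compounds are modest, and nothing available explains these differences.

Compound 1 and compound 2 differ in both the halogen and its place on the ring, so a 4-chlorophenyl group would be needed to separate the two. Also open, as far as these compounds go, is how an amine or a carboxylic acid on this ring would compare with hydrogen.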